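The source may hold more compounds than are shown below. What is called first, only, known or untested is meant among the compounds shown, and "the series" means these compounds.

Measured compounds:
compound 1 `CCc1ncn2c(O)nncc12`: > 48000 nM
compound 2 `CCCc1ncn2c(O)nncc12`: > 48000 nM
compound 3 `Cc1ncn2c(O)nncc12`: > 48000 nM

Each of these three values in a functional assay for inhibition, with Homo sapiens as the target (a lower number here means a stronger inhibitor, a higher number a weaker inhibitor), is a limit of the assay, not a measured number. Compound 3 therefore stands only at a limit, and the two other values shown sit at the same limit, as the limit of > 48000 nM in this assay, at which 3 of the 3 values shown sit, records. The three compounds differ only in the saturated chain on the shared core, and the steps between them, a step that the two limits leave unreadable from compound 1 to compound 2, a step that the two limits leave unreadable from compound 1 to compound 3 and a step that the two limits leave unreadable from compound 2 to compound 3, cannot be given a size, since the limit of > 48000 nM in this assay, at which 3 of the 3 values shown sit, covers all three values.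

Compound 4 `Cc1ncn2c(N(C)C)nncc12` is the one not yet measured. It differs from compound 3 as follows: dimethylamino in place of hydroxy on an aromatic carbon. None of the three measured steps concerns this part of the core; all of them change the saturated chain, so no measured step bears on the change from compound 3 to compound 4, and no size or direction can be read for it from the numbers shown. With only limits to go on, compound 3 is taken as a weak point of departure, and the step that the limit leaves unreadable from compound 3 to compound 4 is estimated without support from any measured step. For compound 4 the expected value is 60000 nM, estimated to lie in the range from 5000 nM to 500000 nM, and a further limit rather than a number is considered the likelier outcome.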

Compound 4, half-maximal inhibitory concentration: > 48000 nM
Compound 4 ended at the assay's limit (the forecaster's own chance of this, stated with the estimate: 70%); the middle value lies beyond the limit too.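

No new step can be read for compound 3 and compound 4, with dimethylamino in place of hydroxy, because neither value is a number: the limit of > 48000 nM in this assay, at which 4 of the 4 values shown sit. The compounds shown leave open whether any change to the saturated chain or to the group on the aromatic carbon would give a measurable inhibitor.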